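Bis-amidine series: removal of the methoxy group

The source may report more compounds than this note shows. Statements on the series, on what has been measured and on what is new or still open speak of the compounds shown alone.

Of the compounds shown here, three have been measured in a functional assay on SK-MEL-2 cells (Homo sapiens) for inhibition, read by sulforhodamine B assay, with a stated time of 48 h; a higher number here means a weaker inhibitor of growth, a lower number a stronger inhibitor of growth. Compound 1 `N=C(N)c1ccc(-c2ccc(-c3cc(Cl)cc(Cl)c3)s2)s1` gives 2240 nM, compound 3 `N=C(N)c1ccc(-c2ccc(-c3cncc4ccccc34)s2)s1` gives 2000 nM, and compound 2 `COc1ccc(-c2ccc(-c3ccc(C(=N)N)o3)o2)cc1` gives 5710 nM. Compound 2 thus has the highest of the three numbers in this assay; the numbers for compound 1 and compound 3 both lie lower, beyond the usual scatter. Compound 1 and compound 3 lie within the scatter of each other, so no order between them is drawn.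

Compound 4 `N=C(N)c1ccc(-c2ccc(-c3ccccc3)o2)o1` has not yet been measured in this assay. It differs from compound 2 in one place: hydrogen in place of methoxy on an aromatic carbon. Within the data shown here, no pair of measured compounds shows this change, so nothing in the measured numbers tells how large a step it brings. A small step is expected, if any beyond the scatter, with no clear direction.

Compound 4 is estimated to give 5500 nM in this assay, with a range from 2500 nM to 12000 nM. The estimated step from compound 2 is a 1.0-fold lower number from compound 2 to compound 4 (0.02 log units; within the scatter).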

Compound 4, concentration for 50% growth inhibition: 2250 nM
Estimate against measurement, compound 4: 2.4-fold (0.39 log units) above; measured number outside the range, below it.
By their numbers in this assay, from the lowest: compounds 3, 1 and 4 (each within the scatter of the next); then compound 2.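

In this assay, hydrogen in place of methoxy on the aromatic carbon para to a large group gives a 2.5-fold lower number from compound 2 to compound 4 (0.40 log units; beyond the scatter) and counts as a modest step. Among these compounds, this is the first step read at this position, and it shows that methoxy is not required there for growth inhibition: the compound carrying hydrogen is the stronger inhibitor of the pair. No measurement on hand bears on the cause of this step.

Open, from the compounds shown here alone, is whether another group at this position, such as an amine, a carboxylic acid or a longer alkoxy chain, would give a number lower or higher than that of compound 4. Among the compounds shown here, also open is whether the same change brings a similar step on the core of compound 1 or compound 3, where no matching pair is available.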